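Swapping the ester group of compound 1 for a cyclopentyl ester

The compounds below may be only part of what the source reports. "The series", "measured", "known", "first", "only" and "open" are said of these compounds alone.

Three compounds share a core and differ in the aromatic group on a saturated ring carbon. In an assay on membranes from CHO cells for displacement of a labelled ligand from adenosine receptor A1 (Homo sapiens), read by scintillation counting, with a stated time of 60 min, tested at 1 uM (a lower number here means less inhibition, a higher number more inhibition at the concentration tested (going by the name of the read-out)), compound 1 `CC1=C(C(=O)OCc2ccccc2)C(c2ccco2)NC(=O)N1` gives 36%, the lowest of the three; compound 2 `CC1=C(C(=O)OCc2ccccc2)C(c2cccs2)NC(=O)N1` gives 45% and compound 3 `CC1=C(C(=O)OCc2ccccc2)C(c2ccsc2)NC(=O)N1` gives 57%. The steps of a number 9 percentage points higher from compound 1 to compound 2 (within the scatter), a number 21 percentage points higher from compound 1 to compound 3 (beyond the scatter) and a number 12 percentage points higher from compound 2 to compound 3 (beyond the scatter) all concern that aromatic group. Compound 4 `CC1=C(C(=O)OC2CCCC2)C(c2ccco2)NC(=O)N1` changes a different place: cyclopentyl in place of benzyl on an oxygen next to a carbonyl group. Going by the values given here, no measured step touches the ester, so nothing here points in either direction, and the expected step of no change at the digits printed from compound 1 to compound 4 (within the scatter) is one not beyond the scatter. Compound 4 is therefore estimated at 36% in this assay, with a range from 12% to 60%.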

Compound 4, a percentage reported as inhibition, at one concentration (the size of the read-out at that concentration, not a potency): 1%
Compound 4: the middle estimate sits 35 percentage points above what was measured; measured number outside the range, below it.
By their numbers in this assay, from the lowest: compound 4; then compounds 1 and 2 (each within the scatter of the next); then compound 3.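

With cyclopentyl in place of benzyl on an oxygen next to a carbonyl group, this assay shows a number 35 percentage points lower from compound 1 to compound 4 (beyond the scatter). Going by these compounds alone, this step is larger than any printed among the aromatic groups, so the ester position, untouched by the earlier compounds, can change the read-out strongly. Nothing available explains why this exchange has such an effect. The compounds shown leave open how an ethyl or a phenethyl ester would read. They also leave open whether cyclopentyl would act the same way alongside thiophen-3-yl instead of furan-2-yl.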